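A few compounds are considered here, and "the series" means these few. Any claim that something is new, unique, unknown or untested is made for them only; others in the source may bear on it.

Compound 1 `Cc1ccccc1-c1cncc(OC[C@@H]2CCCN2C)c1` belongs to a small set of three compounds that share one core and differ only in the aromatic group attached to it. In an assay on membranes from brain for binding affinity to Neuronal acetylcholine receptor; alpha4/beta2 (Rattus norvegicus) (a lower number here means a stronger inhibitor, a higher number a weaker inhibitor), compound 1 gives 1.1 nM, which is the highest number of the three. Compound 2 `CN1CCC[C@H]1COc1cncc(-c2ccccc2C=O)c1` gives 0.56 nM in this assay, and compound 3 `COc1ccc(-c2cncc(OC[C@@H]3CCCN3C)c2)cc1` gives 0.32 nM; the gap between compound 1 and compound 3 lies beyond the scatter, while the change a 2.0-fold lower number from compound 1 to compound 2 (0.29 log units; within the scatter) lies within it. Compound 4 `CN1CCC[C@H]1COc1cncc(-c2cccs2)c1` has not yet been measured. It differs from compound 1 in one place: thiophen-2-yl in place of 2-methylphenyl on an aromatic carbon. Within the data shown here, none of the measured steps tests this exact swap of one aromatic group for another of a different ring size; the only single-point step available, a 2.0-fold lower number from compound 1 to compound 2 (0.29 log units; within the scatter), is a small change within the scatter, and it shows that the attached aromatic group can be altered there without a large shift. On that basis the step from compound 1 to compound 4 is expected to be small, a 1.1-fold lower number from compound 1 to compound 4 (0.04 log units; within the scatter), with no firm direction. Compound 4 is therefore estimated at 1 nM in this assay, with a likely range from 0.3 nM to 4 nM.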

Compound 4, inhibition constant: 0.31 nM
The estimate for compound 4 lay 3.2-fold (0.51 log units) above the measured number; measured number inside the range.
By their numbers in this assay, from the lowest: compounds 4, 3, 2 and 1 (each within the scatter of the next, the first and the last beyond it).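

Replacing 2-methylphenyl with thiophen-2-yl on this aromatic carbon, two atoms from the ring nitrogen, gives a 3.5-fold lower number from compound 1 to compound 4 (0.55 log units; beyond the scatter) in this assay, the first single change from compound 1 with a step that is printed as beyond the scatter. The position therefore accepts a five-membered aromatic ring containing sulfur in place of a six-membered ring of carbon only, and compound 4 lies within the scatter of compound 3, so a six-membered ring is not needed to reach numbers this low. This one swap alters ring size, adds a hetero atom and removes the methyl group together, and no measurement here bears on which of these lies behind the step.

Phenyl without a methyl group and furan-2-yl, which has oxygen where thiophen-2-yl has sulfur, would help separate these changes. The compounds shown also leave open how much the point of attachment matters, as in thiophen-3-yl, and how this position responds to a ring carrying an amine or a carboxylic acid.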